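This account rests on a few compounds, and the source may have more. Where it says the series, first, only, none or still open, it means among the compounds named here.

Measured so far:
compound 1 `Cc1c(CN2CCN(C)CC2)cc(-c2ccc(Cl)cc2)n1-c1ccc(Cl)cc1` — 3.23 ug/mL
compound 2 `Cc1c(CN2CCN(c3ccccc3)CC2)cc(-c2ccc(Cl)cc2)n1-c1ccc(Cl)cc1` — 294 ug/mL

Compound 1 gives the lowest of the two numbers in an ADME assay on THP-1 cells (Homo sapiens) for cytotoxicity, read by trypan blue exclusion, with a stated time of 48 h; on this read-out lower numbers stand for stronger inhibition of growth and higher numbers for weaker inhibition of growth; its nearest neighbour is compound 2, reached by a step that is a 91-fold higher number from compound 1 to compound 2 (1.96 log units; beyond the scatter), where the change is a phenyl in place of methyl on an amine nitrogen in a ring. Compound 3 `Cc1c(CNC2CCCCC2)cc(-c2ccc(Cl)cc2)n1-c1ccc(Cl)cc1` has not yet been measured in this assay. It differs from compound 1 in one place: cyclohexylamino in place of 4-methylpiperazin-1-yl on a saturated chain carbon bound to an aromatic carbon. Going by the values given here, the only measured step touches the same ring amine, and it was large, so this region plainly matters for the read-out; but a phenyl entering on the ring nitrogen is not the same change as a carbocyclic ring with an amine hydrogen replacing the whole ring amine, so the guide is loose. Compound 3 is expected to give a number close to that of compound 1, with the step of a 1.1-fold higher number from compound 1 to compound 3 (0.03 log units; within the scatter) expected to stay within the scatter, and its estimated value is 3.5 ug/mL with a range from 1 ug/mL to 15 ug/mL.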

Compound 3, concentration for 50% growth inhibition: 3.9 ug/mL
Beside the measured number, compound 3's estimate is 1.1-fold (0.05 log units) below it; measured number inside the range.
By their numbers in this assay, from the lowest: compounds 1 and 3 (each within the scatter of the next); then compound 2.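

In this assay, replacing the whole 4-methylpiperazin-1-yl group with cyclohexylamino gives a 1.2-fold higher number from compound 1 to compound 3 (0.08 log units; within the scatter), so a ring of carbon only with a single nitrogen outside it serves here as well as the ring with two hetero atoms. The large change seen earlier, a 91-fold higher number from compound 1 to compound 2 (1.96 log units; beyond the scatter), therefore does not extend to every change made at this group: this position accepts at least one quite different amine with no shift beyond the scatter. Nothing available explains why these two groups give such similar numbers.

The compounds shown leave open whether a nitrogen is needed here at all, which a plain cyclohexyl group would test, and whether a ring is needed, which an open-chain diethylamino group would test. They also leave open whether the large step belongs to phenyl alone or would also appear with ethyl or acetyl on that ring nitrogen.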